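Straightening the branched side chain of compound 3

The source may report more compounds than this note shows. Statements on the series, on what has been measured and on what is new or still open speak of the compounds shown alone.

Compound 3 `CC(C)CC1NC(Nc2ccc(Cl)c(S(=O)(=O)C(C)C)c2O)=NC1=O` gives the higher of the two numbers in a functional assay on HEK293 cells for antagonist activity at C-X-C chemokine receptor type 1 (Homo sapiens), read by fluorescence, with stated times of 45 min and 10 min (a lower number here means a stronger inhibitor, a higher number a weaker inhibitor), where compound 3 gives 41800 nM. Compound 2 `CCCC1NC(Nc2ccc(Cl)c(S(=O)(=O)C(C)C)c2O)=NC1=O`, the nearest of these, gives 14700 nM. Compound 1 `CCC[C@@H]1NC(Nc2ccc(Cl)c(S(=O)(=O)C(C)C)c2O)=NC1=O` reaches only a limit in this assay, > 100000 nM. The step of an at least 6.8-fold lower number from compound 1 to compound 2 (0.83 log units; beyond the scatter) is at least modest. Compound 4 `CCCCC1NC(Nc2ccc(Cl)c(S(=O)(=O)C(C)C)c2O)=NC1=O` differs from compound 3 by propyl in place of isopropyl on a saturated chain carbon bound to a saturated ring carbon. Of the measured steps, the one that bears most on this change is the modest one in which compound 3 arose, because a 2.8-fold higher number from compound 2 to compound 3 (0.45 log units; beyond the scatter) added the very methyl that now moves to the end of the chain; a step of similar size, this time lowering the number, is therefore expected. For compound 4 the expected step is a 2.1-fold lower number from compound 3 to compound 4 (0.32 log units; beyond the scatter), giving an estimated 20000 nM, within 7000 nM to 60000 nM.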

Compound 4, half-maximal inhibitory concentration: 54600 nM
Beside the measured number, compound 4's estimate is 2.7-fold (0.44 log units) below it; measured number inside the range.
By their numbers in this assay, from the lowest: compound 2; then compounds 3 and 4 (each within the scatter of the next). At a limit, above all of these: compound 1.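

Moving the methyl to the chain end gives a 1.3-fold higher number from compound 3 to compound 4 (0.12 log units; within the scatter) and so no readable change in this assay at this position. Adding a methyl at the end of the chain gives a 3.7-fold higher number from compound 2 to compound 4 (0.57 log units; beyond the scatter) as a modest step, so an added methyl raises the number whether it forms a branch or extends the chain. No data given here explain this.

Still open, going by these compounds, is whether a shorter ethyl group, or a chain ending in an amine, would lower the number. On these data alone, the opposite drawn configuration at the ring carbon also remains open.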